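A few compounds are considered here, and "the series" means these few. Any claim that something is new, unique, unknown or untested is made for them only; others in the source may bear on it.

In a functional assay on the whole organism with Mus musculus as the target, with a stated time of 1 h, at a dose of 100 mg/kg by the intraperitoneal route (on this read-out higher numbers stand for more inhibition at the one dose given (going by the name of the read-out) and lower numbers for less inhibition), compound 1 `Fc1ccccc1COc1nc2ccccc2s1` gives 74.6% and compound 2 `Clc1ccccc1COc1nc2ccccc2s1` gives 14.6%, the lower of the two numbers shown, with a number 60 percentage points lower from compound 1 to compound 2 (beyond the scatter). Compound 3 `FC(F)(F)c1ccccc1COc1nc2ccccc2s1` differs from compound 2 by trifluoromethyl in place of chloro on an aromatic carbon. No measured step exchanges chloro for trifluoromethyl, so the single step shown, a number 60 percentage points lower from compound 1 to compound 2 (beyond the scatter), bears on it only indirectly: it tells that a change of the group at this place can shift this assay by a large amount in either direction. For compound 3 a step of a number 25.4 percentage points higher from compound 2 to compound 3 (beyond the scatter) is therefore expected, with wide uncertainty. Compound 3 is estimated at 40%, between 10% and 75%.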

Compound 3, a percentage reported as inhibition, in the whole organism at one dose (the size of the read-out at that dose, not a potency): 9.75%
Estimate against measurement, compound 3: 30.3 percentage points above; the measured number lies below the stated range.
By their numbers in this assay, from the lowest: compounds 3 and 2 (each within the scatter of the next); then compound 1.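

In this assay the exchange of chloro for trifluoromethyl gives a number 4.9 percentage points lower from compound 2 to compound 3 (within the scatter) and so separates neither group from the other at this place on the ring, while the change from fluoro gives a number 64.9 percentage points lower from compound 1 to compound 3 (beyond the scatter). Among these three compounds the large fall is therefore not particular to chloro, and only compound 1 stands apart. Nothing measured here accounts for this. Still open, going by these compounds, is whether a methyl, a methoxy or an amine on this aromatic carbon would hold the read-out of compound 1, and what the unsubstituted ring would give.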